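Working notes: from compound 3 to compound 4

A few compounds are considered here, and "the series" means these few. Any claim that something is new, unique, unknown or untested is made for them only; others in the source may bear on it.

Measured in a functional assay on HFF cells (Homo sapiens) for cytotoxicity; a higher number here means a weaker inhibitor, a lower number a stronger inhibitor:
- compound 1 (`O[C@@H]1[C@@H](CF)OC(n2c(Cl)nc3cc(Cl)c(Cl)cc32)[C@@H]1O`): 32000 nM
- compound 2 (`O[C@@H]1[C@@H](CBr)OC(n2c(Cl)nc3cc(Cl)c(Cl)cc32)[C@@H]1O`): 32000 nM
- compound 3 (`[N-]=[N+]=NC[C@H]1OC(n2c(Cl)nc3cc(Cl)c(Cl)cc32)[C@H](O)[C@@H]1O`): 32000 nM

Compound 3 stands level with compound 1 and compound 2 in this assay, so it offers no separation within this small set. The next compound, compound 4 (`CSC[C@H]1OC(n2c(Cl)nc3cc(Cl)c(Cl)cc32)[C@H](O)[C@@H]1O`), carries methylsulfanyl in place of azido on a saturated chain carbon bound to a saturated ring carbon.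

Three measured exchanges at that same place bear on this change: no change at the digits printed from compound 1 to compound 2 (within the scatter), no change at the digits printed from compound 1 to compound 3 (within the scatter) and no change at the digits printed from compound 2 to compound 3 (within the scatter). Within the data shown here, all three stay within the scatter, and no measured compound goes against this. However, none of the measured compounds carries methylsulfanyl, so the expectation is carried over from other groups and the range is kept generous.

The estimated step is no change at the digits printed from compound 3 to compound 4 (within the scatter), with no step beyond the scatter expected in either direction. For compound 4 the expected value is 32000 nM, with an estimated range of 13000 nM to 80000 nM.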

Compound 4, half-maximal inhibitory concentration: 32000 nM
Beside the measured number, compound 4's estimate shows no gap at the digits printed; the range from low to high includes it.
By their numbers in this assay, from the lowest: compounds 1, 2, 3 and 4 (each within the scatter of the next).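

In this assay the series now holds a group built from carbon and sulfur at this place, on a saturated chain carbon bound to a saturated ring carbon, and the exchange for azido gives no change at the digits printed from compound 3 to compound 4 (within the scatter). The exchanges for the halogens read the same, with no change at the digits printed from compound 2 to compound 4 (within the scatter) and no change at the digits printed from compound 1 to compound 4 (within the scatter), so methylsulfanyl joins fluoro, bromo and azido in a set of four groups with no separation between them. Nothing at hand accounts for this agreement.

Since all four compounds read alike, the series does not yet show any group at this place that moves the number. An amine, a carboxylic acid or a longer chain such as ethylsulfanyl at the same place remains an open question.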